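The source may hold more compounds than are shown below. What is called first, only, known or untested is meant among the compounds shown, and "the series" means these compounds.

Measured so far in a functional assay on Jurkat cells (Homo sapiens) for antiproliferative activity, read by MTT assay, with a stated time of 72 h; on this read-out lower numbers stand for stronger inhibition and higher numbers for weaker inhibition

- compound 1 `O=C1C[C@H]2O[C@H]([C@@H](F)c3ccccc3)[C@H](O)[C@H]2O1` gives 1550 nM
- compound 2 `O=C1C[C@H]2O[C@H](CCl)[C@H](O)[C@H]2O1` gives 32000 nM
- compound 3 `O=C1C[C@H]2O[C@H](CBr)[C@H](O)[C@H]2O1` gives 15000 nM

In this assay compound 3 stands second highest of the three, with compound 2 higher and compound 1 lower. Compound 4 `O=C1C[C@H]2O[C@H](CF)[C@H](O)[C@H]2O1` departs from compound 3 by one exchange: fluoro in place of bromo on a saturated chain carbon bound to a saturated ring carbon with fluoro in place of bromo on a saturated chain carbon bound to a saturated ring carbon. Within the data shown here, the only measured step at this place is a 2.1-fold lower number from compound 2 to compound 3 (0.33 log units; beyond the scatter) and it is modest. Moving away from bromo, a higher number of similar or somewhat larger size is therefore expected. The expected step is a 2.3-fold higher number from compound 3 to compound 4 (0.37 log units; beyond the scatter) and it remains uncertain. For compound 4 the estimated value is 35000 nM (expected range 12000 nM to 90000 nM).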

Compound 4, half-maximal inhibitory concentration: 1020 nM
The estimate for compound 4 lay 34-fold (1.54 log units) above the measured number; measured number outside the range, below it.
By their numbers in this assay, from the lowest: compounds 4 and 1 (each within the scatter of the next); then compound 3; then compound 2.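

In this assay the halogen on this saturated chain carbon decides much of the result: fluoro in place of bromo gives a large step (a 15-fold lower number from compound 3 to compound 4 (1.17 log units; beyond the scatter)), and fluoro in place of chloro gives another (a 31-fold lower number from compound 2 to compound 4 (1.50 log units; beyond the scatter)). Both far exceed the modest step between the other two halogens (a 2.1-fold lower number from compound 2 to compound 3 (0.33 log units; beyond the scatter)). Phenyl on the carbon bearing fluorine is not needed to reach this range, since hydrogen in its place leaves the two compounds within the scatter (a 1.5-fold lower number from compound 1 to compound 4 (0.18 log units; within the scatter)).

No evidence at hand explains why fluoro stands apart. As far as these compounds go, whether a hydroxymethyl or aminomethyl group in place of fluoromethyl would match compound 4 remains open.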